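Morpholine for Thiomorpholine on a Thiocarbonyl Carbon

A few compounds are considered here, and "the series" means these few. Any claim that something is new, unique, unknown or untested is made for them only; others in the source may bear on it.

Three compounds built on closely related cores were measured in a functional assay on HeLa cells (Homo sapiens) for cytotoxicity, read by MTT assay, with a stated time of 72 h, tested at 30 uM; a higher number here means more inhibition of growth at the concentration tested, a lower number less inhibition of growth. Compound 1 `Cc1ccnc(/C(N)=N/NC(=S)N2CCOCC2)c1` gives 45.2% in this assay. Compound 3 `Cc1ccnc(/C(N)=N/NC(=S)N2CCSCC2)c1` gives 78.3% in this assay. Compound 2 `Cc1cccc(/C(N)=N/NC(=S)N2CCSCC2)n1` gives 85.3% in this assay, the highest of the three numbers; its gap to compound 3 lies within the scatter, so no order between those two is claimed, while its gap to compound 1 lies beyond the scatter.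

Compound 3 and compound 1 differ in one place: morpholin-4-yl in place of thiomorpholin-4-yl on a thiocarbonyl carbon. That change produced a step of a number 33.1 percentage points lower from compound 3 to compound 1 (beyond the scatter), a large drop. Compound 2 and compound 3 contain the same atoms joined differently; the difference between the two cores is not broken down here.

Compound 4 `Cc1cccc(/C(N)=N/NC(=S)N2CCOCC2)n1` has not yet been measured in this assay. Among the compounds with values here, it differs from compound 2 by morpholin-4-yl in place of thiomorpholin-4-yl on a thiocarbonyl carbon, the same change as the one between compound 3 and compound 1, made at a place described in the same words. Among the compounds shown this change occurs twice, once measured and once not.

The expectation rests on a single measured step, so it is held loosely. Within the data shown here, compound 4 is expected to fall to about 52%, most likely between 35% and 70%, because a number 33.1 percentage points lower from compound 3 to compound 1 (beyond the scatter) was seen for the one matching pair already measured. The estimated step is therefore a number 33.3 percentage points lower from compound 2 to compound 4 (beyond the scatter), placed beside the earlier one for comparison.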

Compound 4, percent growth inhibition at one concentration: 86.9%
Compound 4: middle estimate off by 34.9 percentage points, on the low side, and the stated range ends below it.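

In this assay the new step reads a number 1.6 percentage points higher from compound 2 to compound 4 (within the scatter), so on the core of compound 2 putting morpholin-4-yl in place of thiomorpholin-4-yl on a thiocarbonyl carbon leaves no difference that can be told from the scatter. The same exchange therefore did not carry from one core to the other in this series, and a step measured on one core gave no safe reading of its size on the other: the same change on two cores in this assay, a number 33.1 percentage points lower (beyond the scatter) from compound 3 to compound 1 and a number 1.6 percentage points higher (within the scatter) from compound 2 to compound 4, 34.7 percentage points apart, beyond the scatter of two such steps. This does not show which of the two outcomes is the usual one, since there are only two matched pairs, and it does not show what in the two cores separates them, as these cores contain the same atoms joined differently and no third core is shown.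

The compounds shown carry only morpholin-4-yl and thiomorpholin-4-yl on the thiocarbonyl carbon, so it stays open whether a piperidin-1-yl or a 4-methylpiperazin-1-yl group there would depend on the core in the same way. All readings also come from a single concentration on one cell line, which leaves open how the two cores would compare across a range of concentrations or on other cells.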